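A few compounds are considered here, and "the series" means these few. Any claim that something is new, unique, unknown or untested is made for them only; others in the source may bear on it.

The measured compounds:
Compound 1, `COc1nc2c(c(=O)n(C)c(=O)n2C)n1CCCC(=O)Nc1ccc(Cl)cc1`: in an assay on isolated protein for inhibition of high affinity 3',5'-cyclic-AMP phosphodiesterase 7A (Homo sapiens), read by cAMP accumulation, with a stated time of 10 min (a higher number here means a weaker inhibitor, a lower number a stronger inhibitor), compound 1 gives > 200000 nM, which is a limit of the assay and not a number.
Compound 2, `COc1nc2c(c(=O)n(C)c(=O)n2C)n1CCCC(=O)Nc1ccc(C(C)(C)C)cc1`: in this assay compound 2 gives 19800 nM.

Compound 2 thus holds the only actual number shown; the other value is a limit. Within the data shown here, the single measured step, an at least 10-fold lower number from compound 1 to compound 2 (1.00 log units; beyond the scatter), rests on that limit at one end, (the limit of > 200000 nM in this assay, at which 1 of the 2 values shown sits), so its true size is known only as a bound. Compound 3, `COc1nc2c(c(=O)n(C)c(=O)n2C)n1CCCC(=O)NCc1ccccc1Cl`, has not been measured. It differs from compound 2 in one place: 2-chlorobenzyl in place of 4-(tert-butyl)phenyl on an amide-type nitrogen. This change brings a chloro back onto the aromatic ring and at the same time exchanges a ring attached directly to the amide nitrogen for a benzyl group. The measured step covers only the first part of this change. Compound 1, which carries the chloro, sits at the limit. Among the measured compounds shown here, no measured compound carries a benzyl group, so that part is untested. For the measured compounds named here, on the one step that bears on it, the number is expected to rise by about a 5.1-fold higher number from compound 2 to compound 3 (0.70 log units; beyond the scatter), with a fair chance of reaching the limit again. Compound 3 is therefore estimated at 100000 nM, within 25000 nM to 400000 nM.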

Compound 3, half-maximal inhibitory concentration: > 200000 nM
Compound 3: no number, only a limit; the forecaster's own chance of this, stated with the estimate: 45%; middle value at least 2.0-fold (0.30 log units) away from the limit.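

On the amide-type nitrogen, 2-chlorobenzyl in place of 4-(tert-butyl)phenyl gives an at least 10-fold higher number from compound 2 to compound 3 (1.00 log units; beyond the scatter) in this assay, so this change costs clear inhibition of the enzyme. Compound 3 gives > 200000 nM, which is a limit of the assay and not a number. Among the three groups shown on this nitrogen, only the 4-(tert-butyl)phenyl group of compound 2 gives a measurable value, while the step between compound 1 and compound 3 cannot be read, so the 4-chlorophenyl and 2-chlorobenzyl groups cannot be ranked against each other: the limit of > 200000 nM in this assay, at which 2 of the 3 values shown sit.

The change to compound 3 alters two things at once, the tert-butyl giving way to a chloro and the ring moving from direct attachment on the nitrogen to attachment through a benzyl carbon, and the loss cannot be divided between the two. Still open, on these data alone, is how a benzyl group carrying tert-butyl would read on this nitrogen, and whether a longer chain between the amide and the ring, or an amine or a carboxylic acid on the ring, would give a measurable value.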